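Series notes: the step from compound 3 to compound 4

The source may report more compounds than this note shows. Statements on the series, on what has been measured and on what is new or still open speak of the compounds shown alone.

Compound 3 `COc1cc(-c2nn(-c3cccc(NC(=O)c4ccc(Cl)c(C(F)(F)F)c4)c3)cc2-c2ccncc2)ccc1Cl` is known in a functional assay on IGROV-1 cells (Homo sapiens) for inhibition, read by sulforhodamine B assay, with a stated time of 48 h (a higher number here means a weaker inhibitor of growth, a lower number a stronger inhibitor of growth), only as a limit, > 32500 nM. Compound 1 `COc1cc(-c2nn(-c3cccc(NC(=O)c4cccc(C(F)(F)F)c4)c3)cc2-c2ccncc2)ccc1Cl` likewise sits at a limit, > 50000 nM. Within the data shown here, compound 2 `COc1cc(-c2nn(-c3cccc(NC(=O)Nc4ccc(Cl)c(Cl)c4)c3)cc2-c2ccncc2)ccc1Cl` gives 3480 nM in this assay and is the one member of the set with a number rather than a limit. Compound 4 `COc1cc(-c2nn(-c3cccc(NC(=O)Nc4ccc(Cl)c(C(F)(F)F)c4)c3)cc2-c2ccncc2)ccc1Cl` differs from compound 3 by (4-chloro-3-(trifluoromethyl)phenyl)amino in place of 4-chloro-3-(trifluoromethyl)phenyl on a carbonyl carbon. The closest measured change of this kind is an at least 14-fold lower number from compound 1 to compound 2 (1.15 log units; beyond the scatter), and an at least 9.3-fold higher number from compound 2 to compound 3 (0.97 log units; beyond the scatter) points the same way when read in reverse. The same kind of step is therefore expected for compound 4, namely an at least 8.1-fold lower number from compound 3 to compound 4 (0.90 log units; beyond the scatter), bringing it near compound 2. Compound 4 is estimated at 4000 nM, with a range of 1500 nM to 15000 nM, in this assay.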

Compound 4, concentration for total growth inhibition: 4220 nM
Compound 4: middle estimate off by 1.1-fold (0.02 log units), on the low side; low and high end bracket the measured number.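

In this assay, with the 4-chloro-3-(trifluoromethyl)phenyl group held fixed, the amino link on the carbonyl carbon alone gives an at least 7.7-fold lower number from compound 3 to compound 4 (0.88 log units; beyond the scatter), a size bounded by a limit: the limit of > 32500 nM in this assay, at which 1 of the 4 values shown sits. Among the amino-linked pair, a 1.2-fold higher number from compound 2 to compound 4 (0.08 log units; within the scatter), so that exchange leaves the read-out unresolved. The wider step an at least 11-fold lower number from compound 1 to compound 4 (1.07 log units; beyond the scatter) is likewise only a bound set by a limit: the limit of > 50000 nM in this assay, at which 1 of the 4 values shown sits.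

As far as these compounds go, whether a methylamino group or an oxygen link on the carbonyl carbon would match the amino link remains open. No compound shown has a carboxylic acid on the terminal aromatic ring.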